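The compounds below may be only part of what the source reports. "The series", "measured", "known", "first", "only" and "open" are said of these compounds alone.

Measured compounds in this series:

compound 1, `COc1ccccc1N1CCN(C(=O)CCc2c(-c3ccc(Cl)cc3)[nH]c3cccc(Cl)c23)CC1`, 950 nM
compound 2, `COc1ccccc1N1CCN(C(=O)CCc2c(-c3ccc(Cl)cc3)[nH]c3c(Cl)cc(Cl)cc23)CC1`, 14 nM
compound 3, `Cn1c(-c2ccc(Cl)cc2)c(CCC(=O)N2CCC(O)(Cc3ccccc3)CC2)c2cc(Br)ccc21`, 0.22 nM

In an assay on CHO cells for displacement of a labelled ligand from Substance-P receptor (Homo sapiens) (a higher number here means a weaker inhibitor, a lower number a stronger inhibitor), compound 3 gives the lowest number of the three. The nearest of the others is compound 2, whose value lies beyond the scatter above that of compound 3; compound 1 stands furthest away, again well beyond the scatter. Compound 3 is thus the strongest inhibitor among the measured compounds in this assay.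

Compound 4, `Cn1c(-c2ccc(Cl)cc2)c(CCC(=O)N2CCC(O)(Cc3ccccc3)CC2)c2cc(N3CCCCC3)ccc21`, has not yet been measured. It differs from compound 3 in one place: piperidin-1-yl in place of bromo on an aromatic carbon. Going by the values given here, no measured pair shows a change of this kind, so no step can be read off from the existing numbers; what is known is the value of compound 3 alone.

For compound 4 the step in this assay, a 2.3-fold higher number from compound 3 to compound 4 (0.36 log units; beyond the scatter), is expected to be small, toward a higher number if any, and quite possibly within the scatter. As far as these compounds go, compound 4 is therefore estimated at 0.5 nM, with a range from 0.1 nM to 3 nM, the width reflecting that the change is untested.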

Compound 4, half-maximal inhibitory concentration: 3.3 nM
The estimate for compound 4 lay 6.6-fold (0.82 log units) below the measured number; the whole stated range lies below it.
By their numbers in this assay, from the lowest: compound 3; then compound 4; then compound 2; then compound 1.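

This position, on an aromatic carbon meta to a fused ring and para to a fused ring, now has its first direct reading in this assay: piperidin-1-yl in place of bromo gives a 15-fold higher number from compound 3 to compound 4 (1.18 log units; beyond the scatter), a large step beyond the scatter. The position is therefore sensitive to this change, yet a group of six heavy atoms with a non-aromatic ring is still accommodated, since compound 4 gives 3.3 nM. No available measurement speaks to what lies behind the step.

With a single step at this position, the loss of bromo, the size of the entering ring and its nitrogen cannot be told apart, so the rise in the number cannot be assigned to any one of them. Hydrogen or chloro at this carbon, and morpholin-4-yl or dimethylamino as amines of different shape, would help to separate these contributions, and it also remains open whether the same change would give a step of similar size on the core of compound 2.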